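Imidazole for pyrrolidine on the cyanomethyl carbamate chain

The compounds below may be only part of what the source reports. "The series", "measured", "known", "first", "only" and "open" are said of these compounds alone.

Two carbamates carrying a nitrile on the chain nitrogen have been measured for cytotoxicity in an ADME assay on MRC5 cells (Homo sapiens) for cytotoxicity; on this read-out lower numbers stand for stronger inhibition and higher numbers for weaker inhibition. Compound 1 `N#CCN(CCCCN1CCCC1)C(=O)OCc1ccccc1` carries a pyrrolidine at the end of the four-carbon chain. In this assay compound 1 gives > 64000 nM, which is a limit of the assay and not a number. Compound 2 `N#CCN(CCCCN1CCN(c2ccc(F)cc2)CC1)C(=O)OCc1ccccc1` carries an aryl piperazine in the same position. In this assay compound 2 also reaches only > 64000 nM, again a limit rather than a number. Compound 1 therefore stands at the limit of > 64000 nM in this assay, at which 2 of the 2 values shown sit, and nothing in the shown values separates it from compound 2.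

Compound 3 `N#CCN(CCCCn1ccnc1)C(=O)OCc1ccccc1` has not yet been measured. It differs from compound 1 by 1H-imidazol-1-yl in place of pyrrolidin-1-yl on a saturated chain carbon, four bonds along the chain from an amide-type nitrogen. Going by the values given here, the two measured compounds suggest no step in this assay beyond the scatter for this kind of change, so the expected step is a number no higher from compound 1 to compound 3 (the limit leaves the size open), which is to say none beyond the scatter. Compound 3 is accordingly expected to give about 64000 nM in this assay, within a range from 20000 nM to 200000 nM, and most likely to be reported only as a limit.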

Compound 3, half-maximal inhibitory concentration: > 64000 nM
Compound 3: no number, only a limit; the forecaster's own chance of this, stated with the estimate: 85%; the middle value sits exactly at the limit.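

In this assay compound 3 gives > 64000 nM, which is a limit of the assay and not a number. Compound 1 also stands at a limit, so no step between compound 1 and compound 3 can be read: the limit of > 64000 nM in this assay, at which 3 of the 3 values shown sit.

The compounds shown leave open whether 1H-imidazol-1-yl and pyrrolidin-1-yl differ at all on this read-out.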